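The source may hold more compounds than are shown below. What is called first, only, known or untested is meant among the compounds shown, and "the series" means these compounds.

Measured in a functional assay on MDA-MB-231 cells (Homo sapiens) for inhibition, read by MTT assay, with a stated time of 48 h; on this read-out lower numbers stand for stronger inhibition of growth and higher numbers for weaker inhibition of growth:
compound 1 `S=C(Nc1ccc(Cl)cc1)Nc1ccc2ncnc(Nc3cccc(Br)c3)c2c1`: 8200 nM
compound 2 `S=C(Nc1cc(Cl)cc(Cl)c1)Nc1ccc2ncnc(Nc3cccc(Br)c3)c2c1`: 3000 nM

Compound 2, at 3000 nM, holds the lower of the two numbers. Next comes compound 3 `CNC(=S)Nc1ccc2ncnc(Nc3cccc(Br)c3)c2c1`, with this change: methyl in place of 3,5-dichlorophenyl on an amide-type nitrogen. For the measured compounds named here, only one measured step bears on this: a 2.7-fold lower number from compound 1 to compound 2 (0.44 log units; beyond the scatter). Going by the values given here, that step puts 3,5-dichlorophenyl in place of 4-chlorophenyl, so a ring remains on both sides of it, and no measured compound shows what losing that ring does. With this little evidence, the expectation in this assay is a somewhat larger step towards a higher number, with the direction itself uncertain. The expected change is a 4.0-fold higher number from compound 2 to compound 3 (0.60 log units; beyond the scatter). The estimate for compound 3 is 12000 nM, within a range of 3500 nM to 40000 nM.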

Compound 3, concentration for 50% growth inhibition: > 30000 nM
Compound 3 was reported as a limit (the forecaster's own chance of this, stated with the estimate: 10%); middle value at least 2.5-fold (0.39 log units) away from the limit.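

For the compounds shown here, until now every compound carried a ring on the amide-type nitrogen, and this is the first reading of a small alkyl group there in this assay: compound 3 gives > 30000 nM, which is a limit of the assay and not a number. Methyl in place of 3,5-dichlorophenyl means an at least 10-fold higher number from compound 2 to compound 3 (1.00 log units; beyond the scatter), and methyl in place of 4-chlorophenyl means an at least 3.6-fold higher number from compound 1 to compound 3 (0.56 log units; beyond the scatter), so both ring-bearing compounds separate from the methyl compound. The full size of both steps stays unread: the limit of > 30000 nM in this assay, at which 1 of the 3 values shown sits.

Still open, on these data alone, is whether a ring is required on this nitrogen, or whether a longer chain such as butyl, or a benzyl group, would restore growth inhibition. An unsubstituted phenyl there would separate the contribution of the ring from that of its chlorines.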